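The compounds below may be only part of what the source reports. "The series", "measured", "known", "first", "only" and "open" are said of these compounds alone.

Measured compounds in a functional assay on HT-29 cells (Homo sapiens) for antiproliferative activity, read by MTT assay, with a stated time of 72 h; a lower number here means a stronger inhibitor, a higher number a weaker inhibitor:
- compound 1, `COc1cc(-c2nc(N(C)C)sc2-c2ccc(C)cc2)cc(OC)c1OC`: 3920 nM
- compound 2, `COc1cc(-c2nc(N(C)C)sc2-c2ccc(C(F)(F)F)cc2)cc(OC)c1OC`: > 10000 nM, a limit of the assay and not a number
- compound 3, `COc1cc(-c2nc(C)sc2-c2ccc(C)cc2)cc(OC)c1OC`: 722 nM

Two changes are traced across these three compounds. The first, (methyl in place of dimethylamino on an aromatic carbon), alters the shared core itself, and a 5.4-fold lower number from compound 1 to compound 3 (0.73 log units; beyond the scatter). Compound 3 thus sits at the lowest of the two numbers in this assay, with compound 1 the nearest.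

The second change, (trifluoromethyl in place of methyl on an aromatic carbon), sits on the outer phenyl ring. Here an at least 2.5-fold higher number from compound 1 to compound 2 (0.40 log units; beyond the scatter); the size of this step is bounded only from below, because of the limit of > 10000 nM in this assay, at which 1 of the 3 values shown sits.

Compound 4, `COc1cc(-c2nc(C)sc2-c2ccc(C(F)(F)F)cc2)cc(OC)c1OC`, is not yet measured in this assay. Its difference from compound 3 is trifluoromethyl in place of methyl on an aromatic carbon, the same change as that from compound 1 to compound 2, made on the core of compound 3 instead.

Beside the measured step from compound 1 to compound 2, compound 4 is expected to show a 4.2-fold higher number from compound 3 to compound 4 (0.62 log units; beyond the scatter) in this assay, a step of similar or somewhat larger size; this rests on the known step of an at least 2.5-fold higher number from compound 1 to compound 2 (0.40 log units; beyond the scatter) and on the starting point of compound 3 at 722 nM. The estimate for compound 4 in this assay is 3000 nM, expected to lie between 1500 nM and 10000 nM, with some chance that only a limit is reported for compound 4.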

Compound 4, half-maximal inhibitory concentration: 396 nM
The estimate for compound 4 lay 7.6-fold (0.88 log units) above the measured number; the measured number lies below the stated range.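

In this assay, trifluoromethyl in place of methyl on an aromatic carbon gives a 1.8-fold lower number from compound 3 to compound 4 (0.26 log units; within the scatter), and the step seen on the core of compound 1 does not carry over to the core of compound 3: the same change on two cores in this assay, an at least 2.5-fold higher number (0.40 log units; beyond the scatter) from compound 1 to compound 2 and a 1.8-fold lower number (0.26 log units; within the scatter) from compound 3 to compound 4, at least 4.6-fold (0.66 log units) apart, beyond the scatter of two such steps. Methyl in place of dimethylamino on an aromatic carbon gives an at least 25-fold lower number from compound 2 to compound 4 (1.40 log units; beyond the scatter), which also differs from the same change made with a methyl group on the outer phenyl ring: the same change on two cores in this assay, a 5.4-fold lower number (0.73 log units; beyond the scatter) from compound 1 to compound 3 and an at least 25-fold lower number (1.40 log units; beyond the scatter) from compound 2 to compound 4, at least 4.6-fold (0.66 log units) apart, beyond the scatter of two such steps. Compound 2 carries a limit and not a number, which leaves the true size of both gaps unknown; the two pairs show that these steps depend on the partner group in this small set, but they give no rule for other cores: the limit of > 10000 nM in this assay, at which 1 of the 4 values shown sits.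

Still open, as far as these compounds go, is whether this dependence extends to a nitrile or a chlorine on the outer phenyl ring, or to an ethyl chain or a primary amine in place of methyl or dimethylamino on the shared core. Also open, from the compounds shown here alone, is whether the same pairing of groups behaves alike outside this assay.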